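This account rests on a few compounds, and the source may have more. Where it says the series, first, only, none or still open, it means among the compounds named here.

Three compounds sharing one core were tested in a functional assay on CRL2813 cells (Homo sapiens) for antiproliferative activity, read by sulforhodamine B assay, with a stated time of 5 days; on this read-out lower numbers stand for stronger inhibition and higher numbers for weaker inhibition. Compound 1 `Cc1ccc(NC(=O)Nc2ccc(Cl)c(C(F)(F)F)c2)cc1O` gives 1600 nM, compound 2 `COc1cc(NC(=O)Nc2cc(C(F)(F)F)cc(C(F)(F)F)c2)ccc1C` gives 500 nM, and compound 3 `COc1cc(NC(=O)Nc2ccc(Cl)c(C(F)(F)F)c2)ccc1C` gives 2800 nM. Compound 3 and compound 1 differ by a single change, (hydrogen in place of methyl on an oxygen on an aromatic ring), which produced a 1.8-fold lower number from compound 3 to compound 1 (0.24 log units; within the scatter). The difference between the cores of compound 2 and compound 3 is not broken down here; compound 2 holds the lowest of the three numbers, beyond the scatter from both others. Compound 4 `Cc1ccc(NC(=O)Nc2cc(C(F)(F)F)cc(C(F)(F)F)c2)cc1O` carries the same change as that one, (hydrogen in place of methyl on an oxygen on an aromatic ring), made at the same place. Because a 1.8-fold lower number from compound 3 to compound 1 (0.24 log units; within the scatter) stayed within the scatter, only a small step is expected here, roughly a 1.4-fold lower number from compound 2 to compound 4 (0.15 log units; within the scatter). On that basis compound 4 is estimated at 350 nM, most likely between 150 nM and 900 nM.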

Compound 4, half-maximal inhibitory concentration: 1200 nM
Estimate against measurement, compound 4: 3.4-fold (0.54 log units) below; measured number outside the range, above it.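

Replacing methoxy with hydroxy on the core of compound 2 in this assay gave a 2.4-fold higher number from compound 2 to compound 4 (0.38 log units; beyond the scatter), so this change did not carry over unaltered from one core to the other. The two steps do not agree: the same change on two cores in this assay, a 1.8-fold lower number (0.24 log units; within the scatter) from compound 3 to compound 1 and a 2.4-fold higher number (0.38 log units; beyond the scatter) from compound 2 to compound 4, 4.2-fold (0.62 log units) apart, beyond the scatter of two such steps. This shows that, for these two pairs, a step measured on one core is a poor guide to the same step on the other, but two pairs cannot show which part of the cores is responsible or predict the step on a third core.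

On these data alone, it remains open how an ethoxy group or a longer chain on the oxygen would compare. An amine in place of the hydroxy is also left open.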